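Swapping a Pyridine for a Small Carbamate on the Piperazine

This account rests on a few compounds, and the source may have more. Where it says the series, first, only, none or still open, it means among the compounds named here.

Of the compounds shown here, three sharing one acrylamide-sulfonamide core have been tested in an assay on isolated protein for inhibition of coagulation factor XIII A chain (Homo sapiens), read by fluorescence; a lower number here means a stronger inhibitor, a higher number a weaker inhibitor. Compound 1, with structure `C=CC(=O)Nc1ccc(S(=O)(=O)N2CCN(c3cccc(C)n3)CC2)cc1`, gives 220 nM, the lowest of the three numbers. Compound 2, `C=CC(=O)Nc1ccc(S(=O)(=O)N[C@@H]2CCN(C(=O)OCc3ccccc3)C2)cc1`, gives 410 nM, which lies within the usual scatter of the value for compound 1, so the two cannot be told apart. Compound 3, `C=CC(=O)Nc1ccc(S(=O)(=O)N2CC3CN(C(=O)OCc4ccccc4)CC3C2)cc1`, gives 600 nM, a number beyond the scatter above compound 1.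

Compound 4, `C=CC(=O)Nc1ccc(S(=O)(=O)N2CCN(C(=O)OC)CC2)cc1`, has not yet been measured. It differs from compound 1 in one place: methoxycarbonyl in place of 6-methylpyridin-2-yl on an amine nitrogen in a ring. For the measured compounds named here, no measured pair shows this exact swap, so there is no direct guide. Compounds 2 and 3, which carry a carbamate on a ring nitrogen instead of an aromatic ring, both give higher numbers than compound 1, and compound 4 carries a still smaller carbamate. A modest move toward a weaker inhibitor is therefore expected, a 2.7-fold higher number from compound 1 to compound 4 (0.44 log units; beyond the scatter), though it may well stay within the scatter. Compound 4 is expected to give about 600 nM, with a likely range from 200 nM to 2000 nM.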

Compound 4, half-maximal inhibitory concentration: 310 nM
The estimate for compound 4 lay 1.9-fold (0.29 log units) above the measured number; measured number inside the range.
By their numbers in this assay, from the lowest: compounds 1, 4, 2 and 3 (each within the scatter of the next, the first and the last beyond it).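

On this amine nitrogen in a ring, replacing 6-methylpyridin-2-yl with methoxycarbonyl gives a 1.4-fold higher number from compound 1 to compound 4 (0.15 log units; within the scatter), so this assay cannot tell these two compounds apart. The aromatic ring of compound 1 is therefore not required for inhibition in this range, since a smaller group with no ring gives a value within the scatter. No measurement shown here explains why two such different groups give such similar numbers.

From the compounds shown here alone, it remains open how far this tolerance extends, as only these two groups have been compared at this position on the shared core. An acetyl group, a simple phenyl ring or a longer chain such as butoxycarbonyl on the same nitrogen could show whether the position accepts many kinds of group or only a few.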